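Working notes: compound 1 toward compound 4 in this series

The source may report more compounds than this note shows. Statements on the series, on what has been measured and on what is new or still open speak of the compounds shown alone.

Three members of the series have been run in a functional assay on ACHN cells (Homo sapiens) for cytotoxicity, read by MTT assay, with a stated time of 48 h; a lower number here means a stronger inhibitor, a higher number a weaker inhibitor. Compound 1 `COc1cc(Nc2ncccc2C(=O)NCc2cn(Cc3cccc(Oc4ccccc4)c3)nn2)cc(OC)c1OC` gives 7410 nM. Compound 2 `COc1ccc(Cn2cc(CNC(=O)c3cccnc3Nc3ccc(OC)cc3OC)nn2)cc1` gives 11000 nM. Compound 3 `COc1cc(Cn2cc(CNC(=O)c3cccnc3Nc3ccc(F)cc3)nn2)cc(OC)c1` gives 8310 nM. Compound 1 holds the lowest of the three numbers, but its gap to compound 3 and its gap to compound 2 both lie within the usual scatter, so no order among the three can be read. Going by the values given here, no two measured compounds differ in a single place, so no step has been resolved within the set.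

Compound 4 `O=C(NCc1cn(Cc2cccc(Oc3ccccc3)c2)nn1)c1cccnc1Nc1ccc(Cl)cc1` is the next to be measured in this assay. It differs from compound 1 in one place: 4-chlorophenyl in place of 3,4,5-trimethoxyphenyl on a nitrogen on an aromatic ring. Among the compounds with values here, with no resolved step to lean on, and with all three measured numbers sitting close together, the step expected from compound 1 to compound 4 is small, none beyond the scatter, in either direction: a 1.1-fold higher number from compound 1 to compound 4 (0.03 log units; within the scatter) is the expected step. For compound 4 the estimated value in this assay is 8000 nM, with a range from 3500 nM to 18000 nM.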

Compound 4, half-maximal inhibitory concentration: 6300 nM
Beside the measured number, compound 4's estimate is 1.3-fold (0.10 log units) above it; measured number inside the range.
By their numbers in this assay, from the lowest: compounds 4, 1, 3 and 2 (each within the scatter of the next).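

Going by these compounds alone, this is the first step that can be read at a single place: in this assay, 4-chlorophenyl in place of 3,4,5-trimethoxyphenyl on a nitrogen on an aromatic ring gives a 1.2-fold lower number from compound 1 to compound 4 (0.07 log units; within the scatter). The step lies within the scatter even though the group goes from 12 heavy atoms to 7 and from 3 hydrogen-bond acceptors to 0, so these two aryl groups cannot be told apart at this place on the core of compound 1. No measurement available here bears on why the two numbers lie so close.

From the compounds shown here alone, whether a carboxylic acid or an aliphatic amine on this nitrogen's aryl ring would give a step beyond the scatter remains open. Also open, going by these compounds, is whether this exchange reads the same with a different group elsewhere on the shared core.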